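Isopropoxymethyl on the Benzimidazole Side of Compound 1

A few compounds are considered here, and "the series" means these few. Any claim that something is new, unique, unknown or untested is made for them only; others in the source may bear on it.

Measured compounds:
- compound 1 `c1ccc2c(-c3cnc4[nH]nc(-c5nc6ccccc6[nH]5)c4c3)cncc2c1`: 870 nM
- compound 2 `COCc1cccc2[nH]c(-c3n[nH]c4ncc(-c5cccnc5)cc34)nc12`: 33 nM
- compound 3 `CN1CCN(c2ccc3[nH]c(-c4n[nH]c5ncc(-c6cncc7ccccc67)cc45)nc3c2)CC1`: 160 nM

In a functional assay on A-375 cells (Homo sapiens) for antiproliferative activity (on this read-out lower numbers stand for stronger inhibition and higher numbers for weaker inhibition), compound 1 gives 870 nM, the highest of the three numbers shown; its nearest neighbour is compound 3, and compound 2 lies furthest away from it. Compound 4 `CC(C)OCc1cccc2[nH]c(-c3n[nH]c4ncc(-c5cncc6ccccc56)cc34)nc12` has not yet been measured. It differs from compound 1 in one place: isopropoxymethyl in place of hydrogen on an aromatic carbon.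

Within the data shown here, one measured step bears on this change. Going a 5.4-fold lower number from compound 1 to compound 3 (0.74 log units; beyond the scatter), a substituent was put onto an aromatic carbon of the shared core in place of hydrogen, and the number fell. Among the measured compounds shown here, compound 2 carries a methoxymethyl group on the same benzimidazole carbon that compound 4 substitutes, though it also differs elsewhere, so no single step links it to compound 1. Nevertheless compound 2, with its value of 33 nM, shows that substitution at that carbon goes with low numbers. Because compound 3 shows a 5.4-fold lower number from compound 1 to compound 3 (0.74 log units; beyond the scatter), a drop of similar size is expected here, as a 5.8-fold lower number from compound 1 to compound 4 (0.76 log units; beyond the scatter) in this assay. Compound 4 is therefore estimated at 150 nM, with a range from 40 nM to 500 nM.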

Compound 4, half-maximal inhibitory concentration: 910 nM
The estimate for compound 4 lay 6.1-fold (0.78 log units) below the measured number, and the stated range ends below it.
By their numbers in this assay, from the lowest: compound 2; then compound 3; then compounds 1 and 4 (each within the scatter of the next).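

In this assay, isopropoxymethyl in place of hydrogen on this aromatic carbon gives a 1.0-fold higher number from compound 1 to compound 4 (0.02 log units; within the scatter), so compound 1 and compound 4 cannot be told apart on this read-out. Putting a substituent onto an aromatic carbon of the shared core therefore does not always lower the number, as it did with 4-methylpiperazin-1-yl in a 5.4-fold lower number from compound 1 to compound 3 (0.74 log units; beyond the scatter); that step does not carry over to this group at this carbon. No measurement in hand accounts for this result.

On these data alone, it remains open whether any group at this carbon can lower the number in compound 1, for instance an aminomethyl group or a carboxylic acid. As far as these compounds go, it is also open whether 4-methylpiperazin-1-yl placed on this same carbon would repeat the step it gave in compound 3.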